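Lengthening the chain of compound 2

The compounds below may be only part of what the source reports. "The series", "measured", "known", "first", "only" and "open" are said of these compounds alone.

In a functional assay on MCF7 cells (Homo sapiens) for inhibition, read by MTT assay, with stated times of 18 h and 4 h (on this read-out lower numbers stand for stronger inhibition and higher numbers for weaker inhibition), compound 1 (`CCCCCCCCCCCCCCCCOP(=O)(O)OCCSC(=S)N1CCCCCC1`) gives > 100000 nM as a limit of the assay. Compound 2 (`CCCOP(=O)(O)OCCSC(=S)N1CCCCC1`) likewise gives > 100000 nM as a limit of the assay. Going by the values given here, compound 2 thus stands at the limit of > 100000 nM in this assay, at which 2 of the 2 values shown sit, with no measured step to go on. The change to compound 3 (`CCCCCCCCCCOP(=O)(O)OCCSC(=S)N1CCCCC1`) is heptyl in place of hydrogen on a saturated chain carbon, three bonds along the chain from an oxygen on an unsaturated carbon and puts heptyl in place of hydrogen on a saturated chain carbon. In this assay the expected a number no higher from compound 2 to compound 3 (the limit leaves the size open) is none beyond the scatter, in no set direction. For compound 3 the estimate is 100000 nM with an expected range from 30000 nM to 300000 nM on this read-out.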

Compound 3, half-maximal inhibitory concentration: 7240 nM
Compound 3: middle estimate off by 14-fold (1.14 log units), on the high side; measured number below the stated range.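

In this assay, heptyl in place of hydrogen on a saturated chain carbon gives an at least 13-fold lower number from compound 2 to compound 3 (1.14 log units; beyond the scatter), the first sign that this position responds to a change in the chain. Compound 2 at > 100000 nM is a limit of the assay, so the step has a floor and no fixed size. The earlier compounds offered no measured number to set against it: the limit of > 100000 nM in this assay, at which 2 of the 3 values shown sit.

As far as these compounds go, whether a longer chain on the core of compound 3 holds, gains or loses this number stays open, as does the effect of an amine at the chain end. Compound 1 differs from compound 3 in more than one place and gives no reading on chain length alone.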